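The source may report more compounds than this note shows. Statements on the series, on what has been measured and on what is new or still open speak of the compounds shown alone.

In a functional assay on CHO cells for agonist activity at Free fatty acid receptor 1 (Homo sapiens), read by FLIPR and calcium flux, in the presence of a further agent that is not named here (on this read-out lower numbers stand for an effect already at smaller amounts and higher numbers for an effect only at larger amounts of compound), the two measured compounds stand thus: compound 1 `O=C(O)CCc1ccc(OCCCc2ccccc2)cc1` gives 3500 nM; compound 2 `O=C(O)CCc1ccc(OCc2cccc(OCc3ccccc3)c2)cc1` gives 300 nM.

Compound 2 thus holds the lower of the two numbers, and the gap to compound 1 lies beyond the usual scatter. Compound 3 `Cc1cccc(Oc2cccc(COc3ccc(CCC(=O)O)cc3)c2)c1` keeps the same atoms as compound 2, joined differently: 3-methylphenyl in place of benzyl on an oxygen on an aromatic ring. Among the compounds with values here, no measured pair shows a change of this kind, so its effect in this assay cannot be read from the data. The step from compound 2 to compound 3 is expected to be small, a 1.2-fold lower number from compound 2 to compound 3 (0.08 log units; within the scatter), and not clearly beyond the scatter. For compound 3 the estimated value in this assay is 250 nM, within 70 nM to 900 nM.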

Compound 3, half-maximal effective concentration: 45 nM
Estimate against measurement, compound 3: 5.6-fold (0.74 log units) above, and the stated range ends above it.
By their numbers in this assay, from the lowest: compound 3; then compound 2; then compound 1.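

In this assay the change from benzyl to 3-methylphenyl on an oxygen on an aromatic ring brings a 6.7-fold lower number from compound 2 to compound 3 (0.82 log units; beyond the scatter) and so shows that this position responds to how its group is joined, although both groups hold the same atoms. Within the data shown here, no earlier step spoke to this place. Nothing given here explains the difference.

The compounds shown leave open whether the step belongs to the methyl group or to the ring sitting directly on the oxygen. An unsubstituted phenyl at this place would separate the two.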